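Spiro-hydantoin amide side chains: notes toward compound 4

The compounds below may be only part of what the source reports. "The series", "measured", "known", "first", "only" and "open" are said of these compounds alone.

Of the compounds shown here, three of the shared core have been measured in an assay on HEK293 cells for displacement of a labelled ligand from NPC1-like intracellular cholesterol transporter 1 (Homo sapiens); on this read-out higher numbers stand for weaker inhibition and lower numbers for stronger inhibition. Compound 1 `CC(C)(C)c1ccc(C(=O)N2CCC3(CC2)C(=O)N(CC(=O)NCCC(=O)O)CN3c2ccccc2)cc1` gives 11400 nM, the highest of the three numbers. Going by the values given here, compound 2 `CC(C)(C)OC(=O)NCC1CCCN(C(=O)CN2CN(c3ccccc3)C3(CCN(C(=O)c4ccc(C5CCCCC5)cc4)CC3)C2=O)C1` gives 3800 nM, and compound 3 `CS(=O)(=O)NCCNC(=O)CN1CN(c2ccccc2)C2(CCN(C(=O)c3ccc(C4CCCCC4)cc3)CC2)C1=O` gives 2100 nM; both of these lie beyond the scatter below compound 1, though neither differs from compound 1 in one place only, so no single step between measured compounds can be read. Compound 4 `CC(C)(C)c1ccc(C(=O)N2CCC3(CC2)C(=O)N(CC(=O)N2CCCC(CO)C2)CN3c2ccccc2)cc1` follows from compound 1 by 3-(hydroxymethyl)piperidin-1-yl in place of (2-carboxyethyl)amino on a carbonyl carbon. The amide nitrogen thereby becomes part of a ring, as it is in compound 2, which gives 3800 nM. A modest move toward a lower number is expected, the step of a 2.5-fold lower number from compound 1 to compound 4 (0.40 log units; beyond the scatter) being estimated as beyond the scatter. Compound 4 is estimated at 4500 nM, within 1500 nM to 14000 nM.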

Compound 4, half-maximal inhibitory concentration: 8200 nM
Estimate against measurement, compound 4: 1.8-fold (0.26 log units) below, within the range that was stated.
By their numbers in this assay, from the lowest: compounds 3 and 2 (each within the scatter of the next); then compounds 4 and 1 (each within the scatter of the next).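

In this assay, the first step readable at this position is a 1.4-fold lower number from compound 1 to compound 4 (0.14 log units; within the scatter). At this carbonyl carbon, (2-carboxyethyl)amino, with its carboxylic acid and no ring, and 3-(hydroxymethyl)piperidin-1-yl, with its six-membered ring, therefore cannot be told apart on this read-out. Nothing available speaks to why the two groups read alike.

Steps to compound 2 and compound 3 cannot be read, as both differ from compound 1 and compound 4 in more than one place. Open, from the compounds shown here alone, is whether an unsubstituted piperidin-1-yl, a primary amine or a longer chain ending in a carboxylic acid would read differently here.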